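Fluoro for Methyl: An Expected Step in Cell Cytotoxicity

The compounds below may be only part of what the source reports. "The series", "measured", "known", "first", "only" and "open" are said of these compounds alone.

Of the compounds shown here, two have been tested in a functional assay on MOLT-4 cells (Homo sapiens) for cytotoxicity, with a stated time of 72 h; on this read-out lower numbers stand for stronger inhibition and higher numbers for weaker inhibition. Compound 1 `Cc1ccc(/C=C2\CCC/C(=C\c3cccc([N+](=O)[O-])c3)C2=O)cc1` gives 9530 nM in this assay, the lowest of the two numbers shown. Compound 2 `O=C1CCCC/C1=C\c1ccc([N+](=O)[O-])cc1` gives 13900 nM in this assay; the two values lie within the scatter of each other, so no order can be read between them. Compound 3 `O=C1/C(=C/c2ccc(F)cc2)CCC/C1=C\c1cccc([N+](=O)[O-])c1` has not yet been measured. It differs from compound 1 in one place: fluoro in place of methyl on an aromatic carbon. Among the measured compounds shown here, no step between measured compounds shows what this change does in this assay. Because compound 1 gives 9530 nM and the change exchanges one heavy atom for another at the same place, the step of a 1.1-fold lower number from compound 1 to compound 3 (0.02 log units; within the scatter) is expected to stay within the scatter, with no clear direction. Compound 3 is therefore estimated at 9000 nM, with a range from 4500 nM to 18000 nM.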

Compound 3, half-maximal inhibitory concentration: 5120 nM
Compound 3: the middle estimate sits 1.8-fold (0.24 log units) above what was measured; measured number inside the range.
By their numbers in this assay, from the lowest: compounds 3, 1 and 2 (each within the scatter of the next, the first and the last beyond it).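

In this assay, the exchange of 4-methylphenyl for 4-fluorophenyl gives the first step read directly at this place, a 1.9-fold lower number from compound 1 to compound 3 (0.27 log units; within the scatter). The earlier compounds shown here held no such pair, and this one shows that fluoro in place of methyl, on an aromatic carbon para to a large group, leaves the read-out within the usual scatter, so no direction can be given to the change. No measurement at hand bears on this result.

Going by these compounds, whether another group at this place, such as chloro, methoxy or an amine, would carry the number beyond the scatter stays open. This pair alone holds the exchange, so how it would read on any other core is also unknown.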